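Swapping the Pyrrolidine Ring of a Sulfonamide Substituent

The source may hold more compounds than are shown below. What is called first, only, known or untested is meant among the compounds shown, and "the series" means these compounds.

Compound 1 `CN1CCC(CNS(=O)(=O)c2ccccc2Nc2cc(-c3ccc4ccn(C)c4c3)c3nccnc3c2)C1` is one of two compounds measured in an assay for inhibition of 6-phosphofructo-2-kinase/fructose-2,6-bisphosphatase 3 (Homo sapiens), read by ADP-Glo, with a stated time of 2 h (a higher number here means a weaker inhibitor, a lower number a stronger inhibitor), and in that assay compound 1 gives 11 nM, the lowest of the two numbers shown. Its neighbour compound 2 `Cn1ccc2ccc(-c3cc(Nc4ccccc4S(N)(=O)=O)cc4nccnc34)cc21` carries hydrogen on the sulfonamide nitrogen and in this assay compound 2 gives 265 nM; the step of a 24-fold higher number from compound 1 to compound 2 (1.38 log units; beyond the scatter) shows that the group on that nitrogen carries much of the difference between the two.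

Compound 3 `Cn1cc(CNS(=O)(=O)c2ccccc2Nc2cc(-c3ccc4ccn(C)c4c3)c3nccnc3c2)cn1` has not been measured. It differs from compound 1 in a single place: 1-methyl-1H-pyrazol-4-yl in place of 1-methylpyrrolidin-3-yl on a saturated chain carbon bound to a sulfonamide nitrogen. Within the data shown here, the only measured step, from compound 1 to compound 2, removes the whole (1-methylpyrrolidin-3-yl)methyl group rather than exchanging its ring, so it bears on compound 3 only loosely. Since compound 3 keeps a substituted chain on the sulfonamide nitrogen, the expected step is far smaller than that, and a modest weakening is estimated, a 2.7-fold higher number from compound 1 to compound 3 (0.44 log units; beyond the scatter). Compound 3 is therefore expected to give about 30 nM, within a range from 8 nM to 120 nM.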

Compound 3, half-maximal inhibitory concentration: 38 nM
Compound 3: middle estimate off by 1.3-fold (0.10 log units), on the low side; the measured number falls inside the stated range.
By their numbers in this assay, from the lowest: compound 1; then compound 3; then compound 2.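

Exchanging only the ring, 1-methyl-1H-pyrazol-4-yl in place of 1-methylpyrrolidin-3-yl on a saturated chain carbon bound to a sulfonamide nitrogen, gives a 3.5-fold higher number from compound 1 to compound 3 (0.54 log units; beyond the scatter) in this assay and so shows that the ring itself counts at this position, not just the presence of a chain. The pyrazole-bearing group still keeps a clear gain over the unsubstituted sulfonamide, with a 7.0-fold lower number from compound 2 to compound 3 (0.84 log units; beyond the scatter) for hydrogen replaced by (1-methyl-1H-pyrazol-4-yl)methyl on a sulfonamide nitrogen, so both rings shown give lower numbers than hydrogen. No measurement at hand accounts for the difference between the two rings.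

The compounds shown leave open how a phenyl ring or an open-chain dimethylamino group would compare with these two rings on the same saturated chain carbon. They also leave open whether a longer chain carrying either ring on the sulfonamide nitrogen would move the number in either direction.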